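From nitro to fluoro on a shared core

The source may report more compounds than this note shows. Statements on the series, on what has been measured and on what is new or still open speak of the compounds shown alone.

- compound 1 `CCOC(=O)C(=O)Nc1cccc(N(C)CC)c1C#N` 0.3 mg/kg
- compound 2 `CCOC(=O)C(=O)Nc1cccc([N+](=O)[O-])c1C#N` 0.4 mg/kg

In a functional assay on the whole organism with Rattus norvegicus as the target (on this read-out lower numbers stand for an effect already at smaller amounts and higher numbers for an effect only at larger amounts of compound), compound 2 gives 0.4 mg/kg and compound 1 gives 0.3 mg/kg so the two lie within the usual scatter of each other. Compound 3 `CCOC(=O)C(=O)Nc1cccc(F)c1C#N` carries fluoro in place of nitro on an aromatic carbon ortho to a cyano group, and fluoro in place of nitro on an aromatic carbon counts what that change removes and adds. Going by the values given here, one measured step bears on this place, nitro in place of ethyl(methyl)amino, and it stays within the scatter. Resting on a 1.3-fold higher number from compound 1 to compound 2 (0.12 log units; within the scatter) and nothing else, no step beyond the scatter is expected in this assay in either direction, although fluoro itself is untested. The expected step is no change at the digits printed from compound 2 to compound 3 (within the scatter) and remains only an estimate. For compound 3 the expected value is 0.4 mg/kg with 0.12 mg/kg and 1.3 mg/kg as the ends of the estimated range.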

Compound 3, dose for half-maximal effect: 1.2 mg/kg
Estimate against measurement, compound 3: 3.0-fold (0.48 log units) below; low and high end bracket the measured number.
By their numbers in this assay, from the lowest: compounds 1 and 2 (each within the scatter of the next); then compound 3.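

In this assay, this position proves sensitive to what it carries: fluoro in place of nitro gives a 3.0-fold higher number from compound 2 to compound 3 (0.48 log units; beyond the scatter), and fluoro in place of ethyl(methyl)amino gives a 4.0-fold higher number from compound 1 to compound 3 (0.60 log units; beyond the scatter). Nitro and ethyl(methyl)amino had stayed within the scatter of each other, so the earlier pair gave no sign that a swap here could move the dose, and compound 3 now needs a larger dose than either of the others. The change takes out a group of 3 heavy atoms with 2 hydrogen-bond acceptors and puts in a single fluorine with none, but nothing available explains why the dose shifts.

From the compounds shown here alone, whether chloro, methoxy or a primary amine at this position would behave like fluoro or like nitro remains open. Going by these compounds, whether a plain hydrogen there would give a dose nearer compound 2 or compound 3 is equally open.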